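This account rests on a few compounds, and the source may have more. Where it says the series, first, only, none or still open, it means among the compounds named here.

Of the compounds shown here, three built on one shared core have been tested in a functional assay on CCRF-CEM cells (Homo sapiens) for antiproliferative activity, read by MTT assay, with a stated time of 48 h, tested at 50 uM; on this read-out higher numbers stand for a weaker effect at the one concentration tested and lower numbers for a stronger effect. Compound 1 `COc1cccc(C(O)CCn2nc3c(Br)c(Br)c(Br)c(Br)c3n2)c1` gives 2%, compound 3 `OC(CCn1nc2c(Br)c(Br)c(Br)c(Br)c2n1)c1ccc(Br)cc1` gives 0%, and compound 2 `C[C@H](O)CCn1nc2c(Br)c(Br)c(Br)c(Br)c2n1` gives 42%. Compound 2 thus stands with the highest number of the three, the weakest effect, and its nearest neighbour is compound 1. Among the measured compounds shown here, the only measured step, a number 2 percentage points lower from compound 1 to compound 3 (within the scatter), exchanges one aromatic group for another and lies within the scatter. Compound 4 `OCC(O)Cn1nc2c(Br)c(Br)c(Br)c(Br)c2n1` differs from compound 2 elsewhere: 1,2-dihydroxyethyl in place of 2-hydroxypropyl on a saturated chain carbon bound to an aromatic nitrogen. For the measured compounds named here, no measured step touches this part of the chain, so nothing here points to a direction. Because compound 2 gives 42%, compound 4 is expected to lie near it, at an estimated 50% with a range of 20% to 85%. The expected step is a number 8 percentage points higher from compound 2 to compound 4 (within the scatter).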

Compound 4, a percentage reported as activity, at one concentration (the size of the read-out at that concentration, not a potency): 27%
Estimate against measurement, compound 4: 23 percentage points above; the range from low to high includes it.
By their numbers in this assay, from the lowest: compounds 3 and 1 (each within the scatter of the next); then compound 4; then compound 2.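

In this assay, 1,2-dihydroxyethyl in place of 2-hydroxypropyl on a saturated chain carbon bound to an aromatic nitrogen gives a number 15 percentage points lower from compound 2 to compound 4 (beyond the scatter). Among the compounds shown here, this is the first measured step at this part of the chain, and it shows that a small change with no ring involved can strengthen the effect beyond the usual scatter. Nothing available explains this shift. On these data alone, whether an amine or a carboxylic acid in this place would move the read-out further remains open, as does the effect of a longer chain.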